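The compounds below may be only part of what the source reports. "The series", "measured", "known", "first", "only" and "open" are said of these compounds alone.

Measured in a physicochemical assay for lipophilicity; a lower number here means a more polar compound, a higher number a more lipophilic compound:
- compound 1 `Cc1cccc(C2=NC(c3ccccc3)CO2)c1`: 4.11
- compound 2 `COc1ccccc1C1=NC(c2ccccc2)CO1`: 3.76
- compound 3 `Cc1ccc(C2=NC(c3ccccc3)CO2)cc1`: 4.11

Compound 2 stands lowest of the three in this assay, and its gaps to compound 1 and compound 3 both lie beyond the scatter. Compound 4 `CSc1ccccc1C1=NC(c2ccccc2)CO1` has not yet been measured. It differs from compound 2 by methylsulfanyl in place of methoxy on an aromatic carbon, ortho to a large group. For the measured compounds named here, no measured pair shows this exchange, so the expectation rests on the structural change alone: a moderate upward step, beyond the scatter. The expected step is a number 0.49 log units higher from compound 2 to compound 4 (beyond the scatter). For compound 4 the estimated value is 4.25, with an expected range from 3.9 to 4.6.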

Compound 4, partition coefficient: 3.5
For compound 4 the middle estimate is 0.75 log units above the measured one; measured number outside the range, below it.
By their numbers in this assay, from the lowest: compounds 4 and 2 (each within the scatter of the next); then compounds 1 and 3 (each within the scatter of the next).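

In this assay, for the compounds shown here, the first exchange at this position to be read as a matched pair, methylsulfanyl in place of methoxy on an aromatic carbon, ortho to a large group, gives a number 0.26 log units lower from compound 2 to compound 4 (within the scatter) and so leaves the two compounds indistinguishable in this assay. Sulfur for oxygen at this place therefore does not separate them. Nothing available here bears on why the exchange gives this result.

On these data alone, whether an ethoxy group, a chlorine or an amine at this position would give a step beyond the scatter remains open. So does whether the same exchange gives a similar step on other aromatic carbons.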